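One more ring swap, with its number still open

The source may report more compounds than this note shows. Statements on the series, on what has been measured and on what is new or still open speak of the compounds shown alone.

Compound 1 `Cn1ccnc1/C=N/Nc1ccnc2cc(Cl)ccc12` gives 17.1 uM
Compound 2 `Clc1ccc2c(N/N=C/c3ccco3)ccnc2c1` gives 19.9 uM

Both values come from a functional assay on KB cells (Homo sapiens) for cytotoxicity; a lower number here means that less compound is needed, a higher number that more compound is needed for the effect. Within the data shown here, compound 2 stands level with compound 1, since only two numbers exist and they lie within the scatter of each other. Among the measured compounds shown here, the single measured step is a 1.2-fold higher number from compound 1 to compound 2 (0.07 log units; within the scatter). It exchanged one five-membered aromatic ring for another, and a step this size cannot be told apart from repeat measurements.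

Compound 3 `Cc1noc(C)c1/C=N/Nc1ccnc2cc(Cl)ccc12` keeps the shared core and changes the same place again: 3,5-dimethyl-1,2-oxazol-4-yl in place of furan-2-yl on a carbon with a double bond to nitrogen. The new group, 3,5-dimethyl-1,2-oxazol-4-yl, is also a five-membered aromatic ring, on the same carbon with a double bond to nitrogen. For the measured compounds named here, the step measured at this place is the only guide, and one step is thin evidence. Going by the values given here, no measured compound carries this group, so the range must stay wide.

The expected step is a 1.1-fold lower number from compound 2 to compound 3 (0.04 log units; within the scatter), which means no change beyond the scatter is anticipated in this assay. Compound 3 is estimated at 18 uM, with an expected range of 8 uM to 40 uM.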

Compound 3, concentration for half-maximal effect: 171 uM
The estimate for compound 3 lay 9.5-fold (0.98 log units) below the measured number; the measured number lies above the stated range.
By their numbers in this assay, from the lowest: compounds 1 and 2 (each within the scatter of the next); then compound 3.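

In this assay, this position proves sensitive to what it carries: the earlier ring swap stayed within the scatter, but this one gives an 8.6-fold higher number from compound 2 to compound 3 (0.93 log units; beyond the scatter) and, set against the 1-methyl-1H-imidazol-2-yl group, a 10-fold higher number from compound 1 to compound 3 (1.00 log units; beyond the scatter) as well. Compound 1 and compound 2 alone might have suggested that any five-membered aromatic ring serves equally well on the carbon with a double bond to nitrogen, but compound 3 carries such a ring and goes against that reading. 3,5-Dimethyl-1,2-oxazol-4-yl differs from furan-2-yl in several ways at once, with more heavy atoms, an extra hetero atom and two methyl groups, and no measurement at hand explains why the number rises.

Still open, as far as these compounds go, is which of those differences matters, a question that an unsubstituted 1,2-oxazol-4-yl group, lacking both methyl groups, could help to separate. The compounds shown also leave unanswered how a six-membered ring such as phenyl or pyridinyl, or a furan-2-yl group carrying a single methyl, would behave at this place.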